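A distant ring swap and the measured acid dissociation

The compounds below may be only part of what the source reports. "The series", "measured", "known", "first", "only" and "open" are said of these compounds alone.

Compound 1 `COc1ccccc1Oc1ccc2c(NCCCNCc3ccco3)ccnc2c1`: 9.28
Compound 2 `COc1ccc(F)cc1CNCCCNc1ccnc2cc(Oc3cccc(N(C)C)c3)ccc12`: 9.28

Of the compounds shown here, two have been measured in a physicochemical assay for acid dissociation. Compound 1 gives 9.28. Compound 2 gives 9.28, level with compound 1 at the digits shown, so the two stand together within the usual scatter of this assay even though they differ at the aryl ether end and at the end of the amine chain.

Compound 3 `COc1ccc(F)cc1CNCCCNc1ccnc2cc(Oc3ccccc3OC)ccc12` has not yet been measured. It differs from compound 2 in one place: 2-methoxyphenyl in place of 3-(dimethylamino)phenyl on an oxygen on an aromatic ring. This puts the same ring on the ether oxygen that compound 1 carries, while keeping the rest of compound 2 unchanged.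

Among the measured compounds shown here, no step between two measured compounds that differ in only this place exists, so the expectation rests on what compound 1 and compound 2 show. Those two carry different groups at this end and give the same value. For compound 3 the step from compound 2 is therefore expected to be no change at the digits printed from compound 2 to compound 3 (within the scatter), that is, none beyond the scatter. Compound 3 is expected to give about 9.28, within a range from 8.98 to 9.58.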

Compound 3, acid dissociation constant: 9.28
The estimate for compound 3 equals the measured number at the digits printed; the measured number falls inside the stated range.
By their numbers in this assay, from the lowest: compounds 1, 2 and 3 (each within the scatter of the next).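

In this assay the change of 3-(dimethylamino)phenyl to 2-methoxyphenyl on an oxygen on an aromatic ring, with everything else held fixed, gives no change at the digits printed from compound 2 to compound 3 (within the scatter) and so can now be read alone. At the far end of the amine chain, 5-fluoro-2-methoxyphenyl in place of furan-2-yl on a saturated chain carbon bound to an amine nitrogen gives no change at the digits printed from compound 1 to compound 3 (within the scatter) as a second single-place reading. Compound 1 and compound 2 differ in both places at once, so their level values alone could have hidden two steps that cancel, whereas these two separate readings show that neither step lies beyond the scatter.

The compounds shown leave open whether a carboxylic acid or a primary amine on the aryl ether ring, or a longer chain in place of the amine chain, would move this number beyond the scatter. Nothing given here identifies which site in these compounds gives up the proton or accounts for the level values.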